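Phenoxy in Place of Hydrogen: Compound 4 Expected

The source may hold more compounds than are shown below. What is called first, only, known or untested is meant among the compounds shown, and "the series" means these compounds.

Of the compounds shown here, three sharing one core have been measured in an ADME assay on microsomes from liver (Homo sapiens), read by LC-MS, using NADPH, with a stated time of 10 min, tested at 0.5 uM; on this read-out lower numbers stand for a less stable compound and higher numbers for a more stable compound. Compound 1 `Cc1nc2cc(-c3ccccc3)nn2c(-c2cc(F)c3c(c2C)CCCO3)c1C(OC(C)(C)C)C(=O)O` gives 93% in this assay; compound 2 `Cc1ccc(-c2cc3nc(C)c(C(OC(C)(C)C)C(=O)O)c(-c4cc(F)c5c(c4C)CCCO5)n3n2)cc1` gives 95%; compound 3 `Cc1nc2cc(-c3ccc(OCc4ccccc4)cc3)nn2c(-c2cc(F)c3c(c2C)CCCO3)c1C(OC(C)(C)C)C(=O)O` gives 84%. Compound 1 stands second highest of the three: its nearest neighbour is compound 2, with a number 2 percentage points higher from compound 1 to compound 2 (within the scatter), and the furthest is compound 3, with a number 9 percentage points lower from compound 1 to compound 3 (within the scatter). Between the other two, a number 11 percentage points lower from compound 2 to compound 3 (beyond the scatter).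

Compound 4 `Cc1nc2cc(-c3cccc(Oc4ccccc4)c3)nn2c(-c2cc(F)c3c(c2C)CCCO3)c1C(OC(C)(C)C)C(=O)O` differs from compound 1 by phenoxy in place of hydrogen on an aromatic carbon, the new group sitting meta to a large group. The step from compound 1 to compound 3 bears on it most closely, as that step also added an oxygen-linked aromatic group at the same aromatic carbon, and it stayed within the scatter; the step from compound 2 to compound 3 was modest and beyond the scatter. Compound 4 is therefore expected to sit a little lower than compound 1, by about a number 7 percentage points lower from compound 1 to compound 4 (within the scatter), which may still fall within the scatter. Compound 4 is estimated at 86%, between 72% and 95%.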

Compound 4, percent of the compound remaining: 100%
The estimate for compound 4 lay 14 percentage points below the measured number, and the stated range ends below it.
By their numbers in this assay, from the lowest: compounds 3, 1, 2 and 4 (each within the scatter of the next, the first and the last beyond it).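

In this assay, phenoxy in place of hydrogen on an aromatic carbon, meta to a large group, gives a number 7 percentage points higher from compound 1 to compound 4 (within the scatter) and so cannot be told apart from the parent compound on this read-out. Until now, this six-membered aromatic ring had carried only methyl and benzyloxy as additions, and phenoxy now shows that a further oxygen-linked aromatic ring can stand on it while the number stays within the scatter of compound 1. Nothing available here gives a reason for this result.

The compounds shown leave open whether an amine such as morpholine, a carboxylic acid or a longer alkoxy chain at this carbon would read the same. They also leave open whether phenoxy would give a similar number on another carbon of this ring.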